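The source may report more compounds than this note shows. Statements on the series, on what has been measured and on what is new or still open speak of the compounds shown alone.

Measured so far in a functional assay on MCF7 cells (Homo sapiens) for antiproliferative activity; a higher number here means a weaker inhibitor, a lower number a stronger inhibitor:

- compound 1 `Cc1cc(-c2nc3ccccc3s2)ccc1N`: < 1 nM
- compound 2 `CC(=O)N(C(C)=O)c1ccc(-c2nc3ccccc3s2)cc1`: > 100 nM

Going by the values given here, with only these two compounds measured, no step between close neighbours is available. Compound 2 gives > 100 nM, which is a limit of this assay and not a number. Compound 1 gives < 1 nM, which is also a limit.

The next compound is compound 3 `CC(=O)N(C(C)=O)c1ccc(-c2nc3ccccc3s2)cc1C`. It has methyl in place of hydrogen on an aromatic carbon, ortho to a diacetylamino group and meta to a group of 9 heavy atoms (methyl in place of hydrogen on an aromatic carbon). Compound 1 carries the same methyl on the same carbon but has a free amine, and the expectation of a gain draws on compound 1 at < 1 nM. Compound 3 keeps the diacetylamino group of compound 2, so the expectation is a loose one, and another limit reading would not be surprising. A step toward stronger inhibition in this assay, larger than the usual scatter, is expected, and the expected step is an at least 3.3-fold lower number from compound 2 to compound 3 (0.52 log units; beyond the scatter). For compound 3 the estimated value is 30 nM, with an expected range from 1 nM to 300 nM.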

Compound 3, half-maximal inhibitory concentration: > 10000 nM
Compound 3: a limit, no number; the forecaster's own chance of this, stated with the estimate: 45%; middle value at least 330-fold (2.52 log units) from the limit.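

In this assay compound 3 gives > 10000 nM, which is a limit of the assay and not a number, so a methyl on this aromatic carbon, ortho to a diacetylamino group, does not by itself bring a compound with the diacetylamino group to the strength seen for compound 1. The values of compound 2 and compound 3 are both limits, so the step for methyl in place of hydrogen cannot be read, and the methyl may have had no effect or any effect hidden behind those limits. Going by these compounds alone, with the methyl held in place, the exchange of amino for diacetylamino gives an at least 10000-fold higher number from compound 1 to compound 3 (4.00 log units; beyond the scatter), the first readable step, and it places nearly all of the visible difference at the nitrogen substituent rather than at the methyl.

What the methyl does alongside a free amine stays open, as the compounds shown hold no amine without it. Also open, going by these compounds, is what a single acetyl group on that nitrogen, or a longer chain in place of the methyl, would give in this assay.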